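The source may hold more compounds than are shown below. What is called first, only, known or untested is meant among the compounds shown, and "the series" means these compounds.

Three compounds share one core and differ only in the group on the amide-type nitrogen. In a functional assay on MCF7 cells (Homo sapiens) for inhibition, read by MTT assay, with a stated time of 24 h (a lower number here means a stronger inhibitor, a higher number a weaker inhibitor), compound 1 `O=C(Cn1c(=O)c(/C=C\c2ccncc2)nc2ccccc21)Nc1ccccc1` gives > 100000 nM, which is a limit of the assay rather than a number. Compound 2 `O=C(Cn1c(=O)c(/C=C\c2ccncc2)nc2ccccc21)Nc1ccc(F)cc1` gives 49000 nM in this assay. Compound 3 `Cc1ccccc1NC(=O)Cn1c(=O)c(/C=C\c2ccncc2)nc2ccccc21` gives > 100000 nM in this assay, again a limit, so its standing is known only as the limit of > 100000 nM in this assay, at which 2 of the 3 values shown sit. Compound 4 `O=C(Cn1c(=O)c(/C=C\c2ccncc2)nc2ccccc21)Nc1ccc(Cl)c(Cl)c1` differs from compound 3 by 3,4-dichlorophenyl in place of 2-methylphenyl on an amide-type nitrogen. Among the measured steps, an at least 2.0-fold lower number from compound 1 to compound 2 (0.30 log units; that floor lies within the scatter) and an at least 2.0-fold higher number from compound 2 to compound 3 (0.30 log units; that floor lies within the scatter) bear on this change, while a step that the two limits leave unreadable from compound 1 to compound 3. A halogen-bearing phenyl is therefore expected to return a readable number, a step of an at least 2.5-fold lower number from compound 3 to compound 4 (0.39 log units; beyond the scatter). Compound 4 is estimated at 40000 nM, between 12000 nM and 100000 nM.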

Compound 4, half-maximal inhibitory concentration: 47600 nM
The estimate for compound 4 lay 1.2-fold (0.08 log units) below the measured number, and the stated range covers the measured number.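

With 3,4-dichlorophenyl on the amide-type nitrogen, the series shows an at least 2.1-fold lower number from compound 3 to compound 4 (0.32 log units; beyond the scatter) and an at least 2.1-fold lower number from compound 1 to compound 4 (0.32 log units; beyond the scatter) in this assay as floors rather than exact sizes. Set against 4-fluorophenyl, this change gives a 1.0-fold lower number from compound 2 to compound 4 (0.01 log units; within the scatter) and so does not separate these two halogen-bearing phenyl groups. Compound 1 and compound 3 remain limits of the assay, not numbers: the limit of > 100000 nM in this assay, at which 2 of the 4 values shown sit. On these data alone, whether a phenyl carrying an amine or a carboxylic acid would give a lower number stays open. So does the true size of every step that starts from a limit.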